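A Phenyl for a Methyl, Starting From a Limit

The source may hold more compounds than are shown below. What is called first, only, known or untested is meant among the compounds shown, and "the series" means these compounds.

Compound 1 `CCOC(=O)c1ccc(-c2nn(C)c3ccccc23)cc1` gives > 10000 nM in a functional assay on cells (Platelet, Homo sapiens) for inhibition (a higher number here means a weaker inhibitor, a lower number a stronger inhibitor), which is a limit of the assay, not a number.
Compound 2 `NC(=O)c1ccc(-c2nn(Cc3ccccc3)c3ccccc23)cc1` gives > 10000 nM in this assay, again a limit.
Compound 3 `CCNC(=O)c1ccc(-c2nn(Cc3ccccc3)c3ccccc23)cc1` gives > 10000 nM in this assay, again a limit.

Compound 1 therefore stands at the limit, and so do the two other compounds: all three sit at the limit of > 10000 nM in this assay, at which 3 of the 3 values shown sit. Within the data shown here, the single step between measured compounds, a step that the two limits leave unreadable from compound 2 to compound 3, cannot be read, because both of its ends rest on (the limit of > 10000 nM in this assay, at which 3 of the 3 values shown sit).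

Compound 4 `CCOC(=O)c1ccc(-c2nn(-c3ccccc3)c3ccccc23)cc1` differs from compound 1 by phenyl in place of methyl on an aromatic nitrogen. Among the measured compounds shown here, no measured step touches a group on the aromatic nitrogen of the shared core, so none bears on this change, and no direction can be taken from the data. The expectation for compound 4 is thus that the step that the limit leaves unreadable from compound 1 to compound 4 stays near nothing, with the assay most likely reporting a limit once more. Compound 4 is estimated at 12000 nM, between 3000 nM and 40000 nM.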

Compound 4, half-maximal inhibitory concentration: > 10000 nM
Compound 4 was reported as a limit; the forecaster's own chance of this, stated with the estimate: 75%; the middle value is on the limit's open side.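

No new step can be read between compound 1 and compound 4, because each of the two values is only a limit: the limit of > 10000 nM in this assay, at which 4 of the 4 values shown sit.

The compounds shown leave open whether phenyl in place of methyl on an aromatic nitrogen changes inhibition at all in this assay.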